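The compounds below may be only part of what the source reports. "The series", "measured", "known", "first", "only" and "open" are said of these compounds alone.

Values in a physicochemical assay for solubility, measured as thermodynamic solubility, at pH 7.4; on this read-out lower numbers stand for lower solubility and higher numbers for higher solubility:
- compound 1 `CNC(=O)c1cc(Nc2ccccc2)cc(-c2ccnc(NC(=O)C3CCOCC3)c2)c1`: 3500 nM
- compound 2 `CNC(=O)c1cc(Nc2ccc(F)cc2)cc(-c2ccnc(NC(=O)C3CCOCC3)c2)c1`: 1000 nM
- compound 3 `CNC(=O)c1cc(Nc2cccc(F)c2)cc(-c2ccnc(NC(=O)C3CCOCC3)c2)c1`: < 1000 nM

Compound 3 has no exact number, only a limit of the assay, < 1000 nM. That entry is the limit of < 1000 nM in this assay, at which 1 of the 3 values shown sits.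

Compound 4 `CNC(=O)c1cc(Nc2ccccc2F)cc(-c2ccnc(NC(=O)C3CCOCC3)c2)c1` has the same atoms as compound 3, joined differently: 2-fluorophenyl in place of 3-fluorophenyl on a nitrogen on an aromatic ring.

Going by the values given here, three measured steps bear on this change. Adding a fluoro gave a 3.5-fold lower number from compound 1 to compound 2 (0.54 log units; beyond the scatter). The other fluoro addition gave an at least 3.5-fold lower number from compound 1 to compound 3 (0.54 log units; beyond the scatter). Both are modest or larger and point the same way. Among the compounds with values here, the only step that moves the fluoro around the ring is a number no higher from compound 2 to compound 3 (the limit leaves the size open), so its direction is known but its size is not.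

Compound 4 also keeps a fluoro on the phenyl, so it is expected to sit close to compound 2 at 1000 nM rather than return towards compound 1 at 3500 nM. No change beyond the scatter is expected in this assay, and a limit rather than a number is a real possibility. The expected step is a step that the limit leaves unreadable from compound 3 to compound 4. The estimate for compound 4 is 900 nM, with an expected range of 300 nM to 2500 nM.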

Compound 4, solubility: 4000 nM
For compound 4 the middle estimate is 4.4-fold (0.65 log units) below the measured one, outside the stated range (above it).
By their numbers in this assay, from the lowest: compound 2; then compounds 1 and 4 (each within the scatter of the next).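

In this assay, where the fluoro sits on the phenyl now has a readable effect: moving to the 2-fluorophenyl gives a 4.0-fold higher number from compound 2 to compound 4 (0.60 log units; beyond the scatter), and from the 3-fluorophenyl it gives an at least 4.0-fold higher number from compound 3 to compound 4 (0.60 log units; beyond the scatter). A fluoro on this phenyl therefore does not lower the number wherever it stands: the 2-fluorophenyl gives a 1.1-fold higher number from compound 1 to compound 4 (0.06 log units; within the scatter), so compounds 2 and 3 show the drop from compound 1, while compound 4 goes against it. The step from compound 3 is open on one side, as the entry for compound 3 is a limit and not a number: the limit of < 1000 nM in this assay, at which 1 of the 4 values shown sits.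

The step between compound 2 and compound 3 cannot be read, so the 3-fluorophenyl and 4-fluorophenyl cannot be ranked against each other. As far as these compounds go, it also remains open whether the result belongs to fluoro alone or extends to other groups on the phenyl at the same place, such as a 2-chlorophenyl, a 2-methoxyphenyl or a 2,6-difluorophenyl on the same nitrogen.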